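Removing the aryl arm from the shared core: an estimate

This account rests on a few compounds, and the source may have more. Where it says the series, first, only, none or still open, it means among the compounds named here.

Among the compounds with values here, compound 1 `Cc1nc2c3ccccc3ccc2c2nc3c(ccc4ccccc43)c(-c3ccccc3S)c12` stands lowest of the three numbers so far: in a functional assay on HeLa cells (Homo sapiens) for cytotoxicity, read by MTT assay, with a stated time of 48 h (on this read-out lower numbers stand for stronger inhibition and higher numbers for weaker inhibition), compound 1 gives 3190 nM. Its neighbours are compound 2 `Cc1nc2c3ccccc3ccc2c2nc3c(ccc4ccccc43)c(-c3cc([N+](=O)[O-])ccc3N)c12`, which in this assay gives 5770 nM, and compound 3 `Cc1nc2c3ccccc3ccc2c2nc3c(ccc4ccccc43)c(-c3cccc([N+](=O)[O-])c3)c12`, which in this assay gives 50700 nM. The step of a 1.8-fold higher number from compound 1 to compound 2 (0.26 log units; within the scatter) stays within the scatter, whereas a 16-fold higher number from compound 1 to compound 3 (1.20 log units; beyond the scatter) and an 8.8-fold higher number from compound 2 to compound 3 (0.94 log units; beyond the scatter) both go beyond it.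

Compound 4 `Cc1nc2c3ccccc3ccc2c2nc3c(ccc4ccccc43)c(C)c12` differs from compound 1 by methyl in place of 2-sulfanylphenyl on an aromatic carbon. Within the data shown here, none of the measured steps removes the ring itself; they only vary what sits on it. Among the measured compounds shown here, still, the only change that stripped the ring of its hydrogen-bond donor, in compound 3, was the costly one, and compound 4 loses donor, acceptor and ring together. For the measured compounds named here, the step is therefore expected to be a loss, likely beyond the scatter, giving a 7.8-fold higher number from compound 1 to compound 4 (0.89 log units; beyond the scatter), though with wide uncertainty because no step of this kind has been measured.

Compound 4 is estimated at 25000 nM in this assay, within a range from 6000 nM to 100000 nM.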

Compound 4, half-maximal inhibitory concentration: > 80000 nM
Compound 4: no number, only a limit; the forecaster's own chance of this, stated with the estimate: 15%; middle value at least 3.2-fold (0.50 log units) from the limit.
By their numbers in this assay, from the lowest: compounds 1 and 2 (each within the scatter of the next); then compound 3. At a limit, above all of these: compound 4.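

Compound 4 gives no number in this assay, only a limit of the assay: the limit of > 80000 nM in this assay, at which 1 of the 4 values shown sits. The earlier compounds shown here varied only what sits on the aryl ring, whereas this result shows what happens when the whole arm gives way to methyl at this carbon opposite the ring nitrogen: the step is an at least 25-fold higher number from compound 1 to compound 4 (1.39 log units; beyond the scatter), and likewise an at least 13-fold higher number from compound 2 to compound 4 (1.14 log units; beyond the scatter). Against the weakest earlier arm, the step is an at least 1.5-fold higher number from compound 3 to compound 4 (0.19 log units; that floor lies within the scatter), so the data cannot tell whether methyl costs anything relative to 3-nitrophenyl.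

On these data alone, what remains open is whether the ring alone carries any of this effect, as a plain phenyl would test, or whether it depends on the groups on that ring. A 2-aminophenyl without the nitro group, or a phenyl bearing a carboxylic acid, would help separate these possibilities.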